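Amide substituent variation in an aminoketone series

The compounds below may be only part of what the source reports. "The series", "measured", "known", "first", "only" and "open" are said of these compounds alone.

Measured so far:
compound 1, `CCC(=O)NCCC(=O)c1cc(OC)ccc1N`: 0.24%
compound 2, `COc1ccc(N)c(C(=O)CCNC(=O)C2CCCC2)c1`: 0.61%

Both compounds share the same core and differ only in the group on the amide carbonyl carbon. In an assay for inhibition of Nitric oxide synthase, inducible (Homo sapiens), read by scintillation counting, with a stated time of 30 min, tested at 1 mM (on this read-out lower numbers stand for less inhibition and higher numbers for more inhibition at the one concentration tested (going by the name of the read-out)), compound 1 gives 0.24%, and compound 2 gives 0.61%. Going by the values given here, the one step measured so far, a number 0.4 percentage points higher from compound 1 to compound 2 (within the scatter), puts compound 2 with compound 1 inside the scatter: neither number is distinguishable from no inhibition at the concentration tested.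

Compound 3, `COc1ccc(N)c(C(=O)CCNC(=O)c2ccccc2)c1`, is the next member of the series. Its change from compound 2 is phenyl in place of cyclopentyl on a carbonyl carbon. Among the compounds with values here, the only step that bears on it is a number 0.4 percentage points higher from compound 1 to compound 2 (within the scatter), which replaced one saturated group on the same carbonyl carbon with another and produced no movement beyond the scatter. Within the data shown here, no measured step covers an aromatic group at this position, so the expectation rests on that single step alone.

On that basis compound 3 is expected to remain near the floor of the assay, with a step of a number 0.4 percentage points higher from compound 2 to compound 3 (within the scatter) expected. The estimate for compound 3 in this assay is 1%, with a range from -5% to 8%.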

Compound 3, a percentage reported as inhibition, at one concentration (the size of the read-out at that concentration, not a potency): 10.9%
The estimate for compound 3 lay 9.9 percentage points below the measured number; measured number above the stated range.
By their numbers in this assay, from the lowest: compounds 1 and 2 (each within the scatter of the next); then compound 3.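

In this assay the group on a carbonyl carbon whose other neighbour is the amide-type nitrogen now shows an effect on the read-out: phenyl in place of cyclopentyl gives a number 10.3 percentage points higher from compound 2 to compound 3 (beyond the scatter) and phenyl in place of ethyl gives a number 10.7 percentage points higher from compound 1 to compound 3 (beyond the scatter). The two saturated groups, ethyl and cyclopentyl, stay within the scatter of each other, while the phenyl compound stands apart from both, so this position distinguishes among these three groups, though only by a modest step. No supporting data bear on why phenyl differs from the two saturated groups.

Phenyl differs from cyclopentyl in both ring size and aromatic character, so the compounds shown leave open which of the two goes with the higher number; a cyclohexyl group on the same carbonyl carbon would separate them. Also open, from the compounds shown here alone, is whether the step can be extended or lost with a pyridyl ring, a chlorophenyl group or a benzyl group at this position.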